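This account rests on a few compounds, and the source may have more. Where it says the series, first, only, none or still open, it means among the compounds named here.

Of the compounds shown here, three from this series have been tested in an ADME assay on Vero cells (Chlorocebus sabaeus) for cytotoxicity, read by MTT assay, with a stated time of 72 h; a higher number here means a weaker inhibitor, a lower number a stronger inhibitor. Compound 1 `CC(=O)N1N=C(c2ccc(-n3c(C)ccc3C)cc2)OC1c1ccccc1Cl` gives 201000 nM in this assay. Compound 2 `CC(=O)N1N=C(c2ccc(-n3c(C)ccc3C)cc2)OC1c1ccccc1[N+](=O)[O-]` gives 175000 nM. Compound 3 `O=[N+]([O-])c1ccc(-c2nnc(-c3ccc(-n4cccc4)cc3)o2)cc1` gives 258000 nM. Compounds 1 and 2 share a core and differ only by chloro in place of nitro on an aromatic carbon; this change gave a 1.1-fold higher number from compound 2 to compound 1 (0.06 log units; within the scatter). Compound 3 rests on a different core, and the difference between the two cores is not broken down here; its value and those of compounds 1 and 2 all lie within the scatter of one another.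

Compound 4 `Clc1ccc(-c2nnc(-c3ccc(-n4cccc4)cc3)o2)cc1` has not yet been measured. It differs from compound 3 by chloro in place of nitro on an aromatic carbon. This is the same kind of change as that from compound 2 to compound 1, though the place differs: there the chloro sits ortho to a large group, here para to a large group. On that footing the expected step is a 1.1-fold higher number from compound 3 to compound 4 (0.04 log units; within the scatter), resting on the step seen from compound 2 to compound 1 in this assay. Compound 4 is therefore estimated at 280000 nM, with a range from 150000 nM to 520000 nM.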

Compound 4, half-maximal inhibitory concentration: 253000 nM
The estimate for compound 4 lay 1.1-fold (0.04 log units) above the measured number; the measured number falls inside the stated range.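

On the second core, chloro in place of nitro gave a 1.0-fold lower number from compound 3 to compound 4 (0.01 log units; within the scatter) in this assay. Set beside the same change on the first core, the two steps agree, and neither the steps nor the gap between them leaves the scatter: the same change on two cores in this assay, a 1.1-fold higher number (0.06 log units; within the scatter) from compound 2 to compound 1 and a 1.0-fold lower number (0.01 log units; within the scatter) from compound 3 to compound 4, 1.2-fold (0.07 log units) apart, within the scatter of two such steps This shows that, on these two cores, the exchange of nitro for chloro carried over with no detectable shift in this read-out, but it does not show that the same would hold on any other core or in any other assay, and with no step of measurable size on either core, it cannot show whether the two cores would answer alike to a change that did move the number.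

The compounds shown leave open whether another group at this place, such as an amine, a carboxylic acid or a methoxy group, would move the number beyond the scatter. They also leave open what the ring would give with only hydrogen there.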